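Replacing the Fluorophenyl Group on the Amide Carbonyl

This account rests on a few compounds, and the source may have more. Where it says the series, first, only, none or still open, it means among the compounds named here.

In a functional assay on A2780 cells (Homo sapiens) for antiproliferative activity, read by CellTiter-Glo, with a stated time of 72 h (on this read-out higher numbers stand for weaker inhibition and lower numbers for stronger inhibition), three related compounds have been measured so far. Compound 2 (`C[C@H](NC(=O)c1cccc(F)c1)c1ccc(NC(=O)N2CC(c3cccnc3)C2)cc1`) gives 2.3 nM, and compound 1 (`O=C(Nc1ccc(CN2C(=O)c3ccccc3C2=O)cc1)[C@H]1C[C@@H]1c1cccnc1`), built rather differently, gives 27 nM. Compound 3 (`C[C@H](NC(=O)c1cccc(F)c1)c1ccc(NC(=O)N2CC(c3ccc(N)nc3)C2)cc1`) falls between these two at 7.6 nM.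

The next molecule, compound 4 (`C[C@H](NC(=O)[C@@H]1CCCN1C)c1ccc(NC(=O)N2CC(c3ccc(N)nc3)C2)cc1`), keeps all of compound 3 except one group on a carbonyl carbon, where 1-methylpyrrolidin-2-yl stands in place of 3-fluorophenyl: 1-methylpyrrolidin-2-yl in place of 3-fluorophenyl on a carbonyl carbon. The aromatic ring of carbon gives way to a non-aromatic ring with a defined stereocentre.

Among the measured compounds shown here, only one measured step offers any guide: a 3.3-fold higher number from compound 2 to compound 3 (0.52 log units; beyond the scatter). That step placed an amino group on an aromatic carbon, elsewhere in the molecule. No measured pair alters the group being replaced now, so the step shows only how large a single change has been among these compounds. The new swap exchanges a whole ring, a larger edit than that amino group, so a step of similar size towards a higher number seems a cautious guess, though its direction is uncertain. The expected change is a 3.3-fold higher number from compound 3 to compound 4 (0.52 log units; beyond the scatter). For compound 4 the estimated value is 25 nM, with an expected range from 6 nM to 100 nM.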

Compound 4, half-maximal inhibitory concentration: 11 nM
Compound 4: middle estimate off by 2.3-fold (0.36 log units), on the high side; the range from low to high includes it.
By their numbers in this assay, from the lowest: compound 2; then compounds 3 and 4 (each within the scatter of the next); then compound 1.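

In this assay, putting 1-methylpyrrolidin-2-yl in place of 3-fluorophenyl on the carbonyl carbon gives a 1.4-fold higher number from compound 3 to compound 4 (0.16 log units; within the scatter), so this read-out does not separate the two compounds. Among the compounds shown here, this is the first measured change at this position, and it shows that, on this shared core, a six-membered aromatic ring of carbon can give way to a five-membered non-aromatic ring holding a nitrogen and a defined stereocentre with no step beyond the scatter. No supporting data accompany this result to say why so different a group leaves the number within the scatter.

Going by these compounds, a single pair speaks for this position, so it remains open whether the same swap would read alike on the shared core of compound 2, which has a hydrogen where compound 3 carries the amino group. Also open, on these data alone, is how this carbonyl carbon would respond to the opposite stereocentre of the ring, to a pyrrolidin-2-yl without its methyl, to a piperidin-2-yl ring or to an open-chain amine.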